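Chain homologation in a cinnamanilide series: lipophilicity notes

A few compounds are considered here, and "the series" means these few. Any claim that something is new, unique, unknown or untested is made for them only; others in the source may bear on it.

Measured so far:
compound 1 `COc1cc(/C=C/C(=O)Nc2ccccc2)ccc1OCCCCN1CCCC1`: 1.6
compound 2 `COc1cc(/C=C/C(=O)Nc2ccccc2)ccc1OCCCCCN1CCCC1`: 1.64

In a physicochemical assay for lipophilicity, using the shake flask method, measured as octanol-water partition, at pH 7.4 (a lower number here means a more polar compound, a higher number a more lipophilic compound), compound 1 gives 1.6 and compound 2 gives 1.64. Going by the values given here, compound 2 is the nearest comparator to the new compound, and its only neighbour is compound 1; the step of a number 0.04 log units higher from compound 1 to compound 2 (within the scatter) lies within the scatter, so the two numbers are not distinguishable. Compound 3 `COc1cc(/C=C/C(=O)Nc2ccccc2)ccc1OCCCCCCN1CCCC1` is not yet measured. It differs from compound 2 by (pyrrolidin-1-yl)methyl in place of pyrrolidin-1-yl on a saturated chain carbon, five bonds along the chain from an oxygen on an aromatic ring, the same kind of change that separates compound 1 from compound 2, moved one bond further out. Among the compounds with values here, the single measured step of this kind, a number 0.04 log units higher from compound 1 to compound 2 (within the scatter), was small. On that basis compound 3 is expected to show a step of a number 0.16 log units higher from compound 2 to compound 3 (within the scatter) in this assay, a slight rise that may well stay within the scatter. The estimate for compound 3 is 1.8, with a range from 1.45 to 2.25.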

Compound 3, partition coefficient: 1.76
Estimate against measurement, compound 3: 0.04 log units above; the measured number falls inside the stated range.
By their numbers in this assay, from the lowest: compounds 1, 2 and 3 (each within the scatter of the next).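

In this assay the change from pyrrolidin-1-yl to (pyrrolidin-1-yl)methyl, now on a saturated chain carbon five bonds along the chain from an oxygen on an aromatic ring, gives a number 0.12 log units higher from compound 2 to compound 3 (within the scatter) and so remains as unresolved here as at the four-bond place. Read as a single change, 2-(pyrrolidin-1-yl)ethyl in place of pyrrolidin-1-yl gives a number 0.16 log units higher from compound 1 to compound 3 (within the scatter) and even this larger difference in the chain does not separate the two compounds. No supporting data bear on this result.

Going by these compounds, whether a longer chain would open a difference beyond the scatter remains unknown. Also open, on these data alone, is how the chain length would read with a different amine at its end, such as morpholin-4-yl in place of the pyrrolidin-1-yl ring.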